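Solubility notes: aryl ether in place of fluorophenyl

The compounds below may be only part of what the source reports. "The series", "measured", "known", "first", "only" and "open" are said of these compounds alone.

Measured so far in a physicochemical assay for solubility, with a stated time of 18 h, at pH 7.4; a lower number here means a less soluble compound, a higher number a more soluble compound:
compound 1, `COc1cccc(CNCCCNc2ccnc3cc(Oc4ccccc4)ccc23)c1O`, 14500 nM
compound 2, `Fc1ccc(-c2ccc3c(NCCCNCc4ccco4)ccnc3c2)cc1`, 32000 nM
compound 3, `COc1cccc(CNCCCNc2ccnc3cc(-c4ccc(F)cc4)ccc23)c1O`, 32000 nM

Compound 2 stands level with compound 3 at the digits given, the two together at the top of the three numbers: no change at the digits printed from compound 2 to compound 3 (within the scatter). For the measured compounds named here, compound 1, the third member, gives 14500 nM; compound 2 gives 32000 nM; no single-point step joins those two.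

Compound 4 is `CN(C)c1cccc(Oc2ccc3c(NCCCNCc4ccco4)ccnc3c2)c1`. It differs from compound 2 in one place: 3-(dimethylamino)phenoxy in place of 4-fluorophenyl on an aromatic carbon.

Going by the values given here, one measured step bears on this change. Going from an aryl ether to a directly bound fluorophenyl, a 2.2-fold higher number from compound 1 to compound 3 (0.34 log units; beyond the scatter). Compound 4 runs that change backwards, replacing the fluorophenyl of compound 2 with an aryl ether, so the corresponding part of the step points toward a lower number in this assay. Among the compounds with values here, the dimethylamino group on the entering ring has no counterpart among the measured compounds, and nothing here tells how it shifts the number.

On that basis a modest drop is expected for compound 4 in this assay: a 1.8-fold lower number from compound 2 to compound 4 (0.25 log units; within the scatter). The estimate for compound 4 is 18000 nM, with a range from 7000 nM to 45000 nM.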

Compound 4, solubility: 14500 nM
For compound 4 the middle estimate is 1.2-fold (0.09 log units) above the measured one; low and high end bracket the measured number.
By their numbers in this assay, from the lowest: compounds 1 and 4 (each within the scatter of the next); then compounds 2 and 3 (each within the scatter of the next).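

In this assay, the change at this aromatic carbon gives a 2.2-fold lower number from compound 2 to compound 4 (0.34 log units; beyond the scatter), so replacing 4-fluorophenyl with an aryl ether on the furan-2-yl series now has a measured step of its own. The earlier step in the opposite direction, a 2.2-fold higher number from compound 1 to compound 3 (0.34 log units; beyond the scatter), was read with the 2-hydroxy-3-methoxyphenyl group on the chain, so the link between an aryl ether and a fluorophenyl at this place now has a reading with each of the two chain groups, and the two steps print the same size. The shown data give no measured property that accounts for the size of either step.

Going by these compounds, the step from compound 2 to compound 4 changes the ring link and adds dimethylamino together, so the share of each remains open, and the matching size of the two steps does not show that dimethylamino contributes nothing. Other groups on the phenoxy ring in place of dimethylamino, such as a morpholine, a methoxy or a carboxylic acid, would show whether the number at this place follows the ether link or responds to the group it carries.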